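The source may report more compounds than this note shows. Statements on the series, on what has been measured and on what is new or still open speak of the compounds shown alone.

Compound 1, with the structure `COc1ccc(C(=O)Nc2ccccc2F)cc1OC1CCCC1`, is one of three compounds tested in an assay on isolated protein for inhibition of phosphodiesterase 4A (Sus scrofa) (on this read-out higher numbers stand for weaker inhibition and lower numbers for stronger inhibition), where compound 1 gives 10700 nM. That is the highest of the two numbers shown. The nearest is compound 2, `COc1ccc(C(=O)Nc2ccccc2Cl)cc1OC`, which in this assay gives 650 nM, a value well below that of compound 1. Compound 3, `COc1ccc(C(=O)Nc2ccccc2Cl)cc1OC(=O)C(C)(C)C`, differs from compound 2 only by (tert-butyl)carbonyl in place of methyl on an oxygen on an aromatic ring. In this assay compound 3 reaches only a limit of the assay, > 1000000 nM, and not a measured number. Going by the values given here, this gives the single measured step, an at least 1500-fold higher number from compound 2 to compound 3 (3.18 log units; beyond the scatter), which rests on (the limit of > 1000000 nM in this assay, at which 1 of the 3 values shown sits).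

Compound 4, `COc1ccc(C(=O)Nc2cccnc2)cc1OC1CCCC1`, is not yet measured. It differs from compound 1 in one place: pyridin-3-yl in place of 2-fluorophenyl on an amide-type nitrogen. Among the compounds with values here, the only measured step concerns a group on an oxygen of the shared core, not the amide-type nitrogen, so it does not bear on this change. Among the measured compounds, compound 1 and compound 2 differ both on the core and on the amide nitrogen, so their values alone cannot be read as a step for the amide partner.

Within the data shown here, with no step to guide the direction, the expected step is a 2.7-fold lower number from compound 1 to compound 4 (0.43 log units; beyond the scatter), a number close to that of compound 1. For compound 4 in this assay the estimate is 4000 nM, expected to lie between 500 nM and 30000 nM.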

Compound 4, half-maximal inhibitory concentration: 550 nM
Beside the measured number, compound 4's estimate is 7.3-fold (0.86 log units) above it, and the stated range covers the measured number.
By their numbers in this assay, from the lowest: compounds 4 and 2 (each within the scatter of the next); then compound 1. At a limit, above all of these: compound 3.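

In this assay the group on the amide-type nitrogen proves to matter a great deal: pyridin-3-yl in place of 2-fluorophenyl gives a 19-fold lower number from compound 1 to compound 4 (1.29 log units; beyond the scatter) and is the first step shown at this place, since the earlier step concerned a group on an oxygen of the shared core. The change removes an aromatic ring of carbon only that carries a fluorine and brings in an aromatic ring with one hetero atom, a nitrogen, so the count of hydrogen-bond acceptors on this group goes from none to one, and this single step cannot separate the loss of the fluorine from the arrival of the ring nitrogen. Nothing measured here gives a reason for the size of this step.

On these data alone, it remains open whether a plain phenyl group on the amide-type nitrogen would behave like 2-fluorophenyl or like pyridin-3-yl, and whether pyridin-4-yl or pyrimidin-5-yl at the same place would give a similar number. Also open, as far as these compounds go, is whether pyridin-3-yl would give a step of similar size on the core of compound 2.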